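Working notes: the step from compound 2 to compound 3

The source may report more compounds than this note shows. Statements on the series, on what has been measured and on what is new or still open speak of the compounds shown alone.

Measured in a functional assay on WIL2-NS cells (Homo sapiens) for cytotoxicity, read by MTT assay, with a stated time of 96 h; on this read-out higher numbers stand for lower toxicity in this test and lower numbers for higher toxicity in this test:
- compound 1 `FC(F)(F)c1cccc(NC(=S)Nc2ccc(I)cc2)c1`: 8000 nM
- compound 2 `FC(F)(F)c1cccc(NC(=S)Nc2ccc(Cl)cc2)c1`: 13000 nM

Going by the values given here, compound 2 gives 13000 nM, which cannot be separated from the only other measured value. Among the compounds with values here, the one measured step, a 1.6-fold higher number from compound 1 to compound 2 (0.21 log units; within the scatter), exchanged one halogen for another on an aromatic carbon. It bears only in part on compound 3 `FC(F)(F)c1cccc(NC(=S)Nc2cccc(Br)c2)c1`, reached from compound 2 by 3-bromophenyl in place of 4-chlorophenyl on an amide-type nitrogen. Within the data shown here, no measured pair tests the change of ring substitution. No step beyond the scatter is therefore expected in this assay. The expected step is a 1.3-fold lower number from compound 2 to compound 3 (0.11 log units; within the scatter). Compound 3 is estimated at 10000 nM, with an expected range of 4500 nM to 22000 nM.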

Compound 3, half-maximal cytotoxic concentration: 9900 nM
Compound 3: middle estimate off by 1.0-fold (0.00 log units), on the high side; the measured number falls inside the stated range.
By their numbers in this assay, from the lowest: compounds 1, 3 and 2 (each within the scatter of the next).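

In this assay 3-bromophenyl in place of 4-chlorophenyl on an amide-type nitrogen gives a 1.3-fold lower number from compound 2 to compound 3 (0.12 log units; within the scatter) and 3-bromophenyl in place of 4-iodophenyl gives a 1.2-fold higher number from compound 1 to compound 3 (0.09 log units; within the scatter) at the same place. Moving from the 4-halophenyl groups to 3-bromophenyl thus brings no step beyond the scatter in these three compounds, though halogen and substitution pattern change together in both steps and cannot be read apart. No evidence at hand bears on these results.

Still open, as far as these compounds go, is whether a phenyl ring carrying an amine or a carboxylic acid instead of a halogen would give a step beyond the scatter at this nitrogen.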